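Quinolone carboxylic acids: chloro to hydroxy on the benzyl ring

The source may report more compounds than this note shows. Statements on the series, on what has been measured and on what is new or still open speak of the compounds shown alone.

Two benzyl-substituted analogues of the shared core have been run so far in a functional assay, tested at 100 uM; on this read-out higher numbers stand for a stronger effect at the one concentration tested and lower numbers for a weaker effect. Compound 1, `O=C(O)c1cn(Cc2ccc(Cl)cc2)c2ccccc2c1=O`, gives 28.7% in this assay. Within the data shown here, compound 2, `COc1ccc(Cn2cc(C(=O)O)c(=O)c3ccccc32)cc1OC`, gives 32.2% in this assay; the two numbers lie within the scatter of one another, so the data do not separate them, and compound 1 is simply the one with the smaller number of the pair.

The next compound, compound 3, `O=C(O)c1cn(Cc2ccc(O)cc2)c2ccccc2c1=O`, has not been measured. Relative to compound 1 the change is hydroxy in place of chloro on an aromatic carbon. Among the measured compounds shown here, no measured pair shows what such a swap does, so there is no step to lean on. For the measured compounds named here, with only two numbers in hand, both close together, the working assumption is that the read-out of compound 3 will stay near that of compound 1, and no movement beyond the scatter in either direction is expected. The step of a number 0.7 percentage points lower from compound 1 to compound 3 (within the scatter) is therefore estimated as essentially flat. For compound 3 the expected value in this assay is 28%, with a range from 12% to 45%.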

Compound 3, a percentage reported as activity, at one concentration (the size of the read-out at that concentration, not a potency): 62.7%
For compound 3 the middle estimate is 34.7 percentage points below the measured one; the whole stated range lies below it.
By their numbers in this assay, from the lowest: compounds 1 and 2 (each within the scatter of the next); then compound 3.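

In this assay, hydroxy in place of chloro on an aromatic carbon, para to a large group, gives a number 34 percentage points higher from compound 1 to compound 3 (beyond the scatter), so the read-out clearly responds to what sits at this position. Among these compounds, the earlier compounds offered no step between analogues differing in one place, which makes this the first direct reading of a change here, and it is a large one. The entering hydroxy counts one hydrogen-bond donor and one hydrogen-bond acceptor against none for chloro, but nothing at hand links that count or any other feature of the group to the rise, and no measurement available speaks to why the read-out moves.

Still open, on these data alone, is whether the rise is particular to hydroxy or would also appear with an amine or a methoxy group at the same place, and whether hydroxy would act the same way elsewhere on this ring. The step also rests on a single pair and on the size of the read-out at one concentration, so it gives no potency for compound 3 and does not establish a trend across the series.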